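Sodium channel inhibition: spiro-cyclobutane to methylcyclopropyl swap

The compounds below may be only part of what the source reports. "The series", "measured", "known", "first", "only" and "open" are said of these compounds alone.

Compound 1 `CN[C@H](CNc1cc(F)c(S(=O)(=O)Nc2ncc(F)s2)cc1Cl)CC1CCC1` — in an ADME assay on HEK293 cells for inhibition of sodium channel protein type 8 subunit alpha (Homo sapiens), read by patch clamp, with a stated time of 5 min (a lower number here means a stronger inhibitor, a higher number a weaker inhibitor), compound 1 gives > 34000 nM, a limit of the assay.
Compound 2 `CN[C@H](CNc1cc(F)c(S(=O)(=O)Nc2ncc(F)s2)cc1Cl)CC12CC(C1)C2` — in this assay compound 2 gives > 34000 nM, also a limit.

Compound 2 stands only at a limit, and the step that the two limits leave unreadable from compound 1 to compound 2 cannot be read, because both values sit at the limit of > 34000 nM in this assay, at which 2 of the 2 values shown sit. Compound 3 `CN[C@H](CNc1cc(F)c(S(=O)(=O)Nc2ncc(F)s2)cc1Cl)CC1(C)CC1` carries a group of 4 heavy atoms (4 carbon; one three-membered non-aromatic ring of carbon only) in place of a group of 5 heavy atoms (5 carbon; 2 four-membered non-aromatic rings of carbon only), on a saturated chain carbon, two bonds along the chain from an amine nitrogen. Among the compounds with values here, no measured step bears readably on this change. Compound 3 is expected to remain near the limit, with a step that the limit leaves unreadable from compound 2 to compound 3 not readable; the estimate is 50000 nM, ranging from 15000 nM to 200000 nM.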

Compound 3, half-maximal inhibitory concentration: > 34000 nM
Compound 3: no number, only a limit; the forecaster's own chance of this, stated with the estimate: 80%; the middle value lies beyond the limit too.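

No step can be read among compound 1, compound 2 and compound 3, because each stands only at a limit: the limit of > 34000 nM in this assay, at which 3 of the 3 values shown sit.

The compounds shown leave open whether cyclobutyl, 1-methylcyclopropyl and the group of two four-membered rings differ at all in this assay.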